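One substituted phenyl group exchanged for another

The compounds below may be only part of what the source reports. "The series", "measured", "known", "first", "only" and "open" are said of these compounds alone.

In a functional assay on U-87MG ATCC cells for antiproliferative activity against U-87 MG (Homo sapiens), read by spectrophotometry, with a stated time of 2 days (a higher number here means a weaker inhibitor of growth, a lower number a stronger inhibitor of growth), compound 3 `Cc1cc(Cl)ccc1Nc1ncc(C(F)(F)F)c(N2Cc3cccc(N(C)S(C)(=O)=O)c3C2)n1` gives 28300 nM and compound 2 `CN(c1cccc2c1CN(c1nc(Nc3cc(C(F)(F)F)cc(C(F)(F)F)c3)ncc1C(F)(F)F)C2)S(C)(=O)=O` gives 16800 nM, two values that lie within the usual scatter of each other. Compound 1 `Cc1ccc(Nc2ncc(C(F)(F)F)c(N3Cc4cccc(N(C)S(C)(=O)=O)c4C3)n2)cc1C` gives > 30000 nM, which is a limit of the assay and not a number.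

Compound 4 `CN(c1cccc2c1CN(c1nc(Nc3cc(Cl)cc(C(F)(F)F)c3)ncc1C(F)(F)F)C2)S(C)(=O)=O` keeps the shared core of compound 3 and differs in one place. It carries 3-chloro-5-(trifluoromethyl)phenyl in place of 4-chloro-2-methylphenyl on a nitrogen on an aromatic ring.

Going by the values given here, only one measured step changes the group at this place while leaving the rest alone: an at least 1.0-fold lower number from compound 1 to compound 3 (0.02 log units; that floor lies within the scatter). The floor of that step lies within the scatter. Its starting point, compound 1, sits at the limit of > 30000 nM in this assay, at which 1 of the 3 values shown sits. That step therefore shows no change beyond the scatter, though it cannot fix an exact size.

Resting on compound 3 at 28300 nM and compound 2 at 16800 nM, a number in the same region is expected, with no clear direction. The expected change is a 1.6-fold lower number from compound 3 to compound 4 (0.20 log units; within the scatter), an estimate that stays within the scatter. For compound 4 the estimated value is 18000 nM, with an expected range from 8000 nM to 30000 nM.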

Compound 4, concentration for 50% growth inhibition: 5500 nM
Beside the measured number, compound 4's estimate is 3.3-fold (0.51 log units) above it, and the stated range ends above it.
By their numbers in this assay, from the lowest: compound 4; then compounds 2 and 3 (each within the scatter of the next). At a limit, above all of these: compound 1.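

In this assay, going by these compounds alone, the group on this nitrogen now makes a difference: 3-chloro-5-(trifluoromethyl)phenyl in place of 4-chloro-2-methylphenyl gives a 5.1-fold lower number from compound 3 to compound 4 (0.71 log units; beyond the scatter), whereas the one earlier step at this place showed no change beyond the scatter. A smaller exchange on the same ring also counts, since chloro in place of trifluoromethyl on an aromatic carbon gives a 3.1-fold lower number from compound 2 to compound 4 (0.48 log units; beyond the scatter), so the outcome depends on the individual groups on that ring and not only on the presence of a substituted phenyl. The remaining step, an at least 5.4-fold lower number from compound 1 to compound 4 (0.73 log units; beyond the scatter), fixes only a floor, since its starting point is a limit and not a number: the limit of > 30000 nM in this assay, at which 1 of the 4 values shown sits.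

The compounds shown cannot say why these exchanges lower the number, nor whether a nitrile, a methoxy group or an amine in place of chloro on this ring would lower it further or raise it again. Also open, on these data alone, is whether a phenyl ring carrying only chloro or only trifluoromethyl would keep the gain, and whether the gain would survive a change elsewhere in the shared core.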